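Compound 4: pyrrolidin-1-yl in place of 2-methoxyethoxy

This account rests on a few compounds, and the source may have more. Where it says the series, first, only, none or still open, it means among the compounds named here.

compound 1 `COCCOc1nc(N)nc2c1ncn2/C=C1/CC1(CO)CO`: > 20000 nM
compound 2 `Nc1nc(NCc2ccccc2)c2ncn(/C=C3/CC3(CO)CO)c2n1`: > 24000 nM
compound 3 `CC(C)Nc1nc(N)nc2c1ncn2/C=C1/CC1(CO)CO`: > 24000 nM
compound 4 `Nc1nc(N2CCCC2)c2ncn(/C=C3/CC3(CO)CO)c2n1`: not yet measured

All the results so far in an ADME assay on Akata cells (Homo sapiens) for cytotoxicity, with a stated time of 7 days (a lower number here means that less compound is tolerated, a higher number that more compound is tolerated), are limits, not numbers. As far as these compounds go, compound 1 gives only the limit > 20000 nM, so its true position is unknown.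

The change to compound 4 is pyrrolidin-1-yl in place of 2-methoxyethoxy on an aromatic carbon. Two measured steps replace the same group in the same place. One is a step that the two limits leave unreadable from compound 1 to compound 2, with benzylamino entering. The other is a step that the two limits leave unreadable from compound 1 to compound 3, with isopropylamino entering. Neither step has a readable size, and neither produced a number in this assay. These two steps give no ground for expecting a change beyond the scatter in either direction, and another limit is the most likely report. The expected step is a step that the limit leaves unreadable from compound 1 to compound 4. For compound 4, the estimated value is 30000 nM, with an expected range of 12000 nM to 60000 nM.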

Compound 4, half-maximal cytotoxic concentration: > 24000 nM
Compound 4: no number, only a limit; the forecaster's own chance of this, stated with the estimate: 85%; the middle value is on the limit's open side.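

In this assay compound 4, like compound 1, compound 2 and compound 3, gives only a limit, so no step among these compounds can be read. Left open is where each true half-maximal cytotoxic concentration lies, and whether exchanging the group on the aromatic carbon shifts it at all.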